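Compound 3: swapping the sulfonyl group for chloromethyl carbonyl

The compounds below may be only part of what the source reports. "The series", "measured", "known", "first", "only" and "open" are said of these compounds alone.

Measured in a functional assay on cells (Homo sapiens) for inhibition, read by MTT assay, with a stated time of 72 h; on this read-out higher numbers stand for weaker inhibition and lower numbers for stronger inhibition:
- Compound 1 `CCOC(=O)Cn1ncc2c(Nc3ccc(NC(=O)CCl)cc3)ncnc21`: 7.27 ug/mL
- Compound 2 `O=C(O)Cn1ncc2c(Nc3ccc(NS(=O)(=O)c4ccc(Br)cc4)cc3)ncnc21`: > 64 ug/mL, a limit of the assay

Working notes on the next step. Compound 2 gives no number in this assay, only a limit: > 64 ug/mL. The size of any step from it therefore cannot be read exactly.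

Compound 3 `O=C(O)Cn1ncc2c(Nc3ccc(NC(=O)CCl)cc3)ncnc21` is still to be measured. It is reached from compound 2 with (chloromethyl)carbonyl in place of (4-bromophenyl)sulfonyl on a nitrogen on an aromatic ring.

For the measured compounds named here, no measured step isolates this change, so the expectation rests on a single reference. The entering (chloromethyl)carbonyl is also carried by compound 1, which gives 7.27 ug/mL. On that basis, a clear move towards stronger inhibition is expected in this assay, though with wide uncertainty. The estimate is an at least 3.2-fold lower number from compound 2 to compound 3 (0.50 log units; beyond the scatter).

For compound 3 the expected value is 20 ug/mL, with an estimated range of 6 ug/mL to 64 ug/mL.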

Compound 3, half-maximal inhibitory concentration: > 100 ug/mL
Compound 3 gave a limit, no number; the forecaster's own chance of this, stated with the estimate: 20%; middle value at least 5.0-fold (0.69 log units) away from the limit.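

In this assay compound 3 reads only as a limit, > 100 ug/mL. With (chloromethyl)carbonyl held in place, hydrogen in place of ethyl on an oxygen next to a carbonyl group gives an at least 13-fold higher number from compound 1 to compound 3 (1.13 log units; beyond the scatter), so (chloromethyl)carbonyl alone does not carry the inhibition seen for compound 1, and among these compounds a measured value appears only with the ethyl on that oxygen. The step between compound 2 and compound 3 cannot be read, as both ends are limits, so swapping (4-bromophenyl)sulfonyl for (chloromethyl)carbonyl on a nitrogen on an aromatic ring gives no ranking of the two groups while the oxygen carries hydrogen.

The compounds shown leave open whether (4-bromophenyl)sulfonyl gives a readable value when the ethyl is kept, which would allow a direct comparison of the two groups on that nitrogen. They also leave open whether a methyl on that oxygen, or an amine in place of that oxygen, would bring back a number in this assay, or whether only the ethyl does so.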